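Swapping the Piperazine for a Piperidine on a Kinase Compound

The source may hold more compounds than are shown below. What is called first, only, known or untested is meant among the compounds shown, and "the series" means these compounds.

Compound 1 `CCC(=O)Nc1cccc(Oc2nc(Nc3ccc(N4CCN(C)CC4)cc3)ncc2Cl)c1` has the higher of the two numbers measured in an assay on isolated protein for inhibition of NUAK family SNF1-like kinase 2 (Homo sapiens), read by ADP-Glo, with a stated time of 60 min, tested at 10 uM, in the presence of a further agent that is not named here (on this read-out higher numbers stand for more inhibition at the one concentration tested (going by the name of the read-out) and lower numbers for less inhibition), giving 82.6%. Its companion, compound 2 `CCC(=O)Nc1cccc(Oc2ccnc(Nc3ccc(N4CCN(C)CC4)cc3)n2)c1`, differs only by hydrogen in place of chloro on an aromatic carbon and gives 48.8% in this assay; that exchange amounts to a number 33.8 percentage points lower from compound 1 to compound 2 (beyond the scatter). Compound 1 therefore stands highest of the two numbers, with compound 2 its nearest neighbour and a long way below it.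

Compound 3 `CCC(=O)Nc1cccc(Oc2nc(Nc3ccc(N4CCC(C)CC4)cc3)ncc2Cl)c1` keeps the chloro of compound 1 and changes the other end of the molecule instead: 4-methylpiperidin-1-yl in place of 4-methylpiperazin-1-yl on an aromatic carbon. Among the measured compounds shown here, the single measured step concerns the chloro, which compound 3 retains, so no measured step bears directly on this exchange, and the data give no guide to the size or direction of its effect. With the chloro kept, a moderate loss is nonetheless assumed as the more cautious expectation, and compound 3 is expected to show a step of a number 12.6 percentage points lower from compound 1 to compound 3 (beyond the scatter). Compound 3 is estimated at 70%, with a range from 45% to 88%.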

Compound 3, a percentage reported as inhibition, at one concentration (the size of the read-out at that concentration, not a potency): 24.8%
Compound 3: middle estimate off by 45.2 percentage points, on the high side; the measured number lies below the stated range.
By their numbers in this assay, from the lowest: compound 3; then compound 2; then compound 1.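

In this assay, the far end of the molecule proves at least as sensitive as the chloro: 4-methylpiperidin-1-yl in place of 4-methylpiperazin-1-yl, on an aromatic carbon para to a large group, gives a number 57.8 percentage points lower from compound 1 to compound 3 (beyond the scatter), a larger step than a number 33.8 percentage points lower from compound 1 to compound 2 (beyond the scatter) that goes with losing the chloro. Keeping the chloro therefore does not by itself preserve the number, and a change that leaves the group at 7 heavy atoms, while going from 2 nitrogen to 1 and from 2 hydrogen-bond acceptors to 1, is enough to produce the largest step among these compounds. Nothing measured here accounts for why this exchange weighs so heavily.

On these data alone, whether the ring nitrogen itself is what counts stays open, as these compounds do not show what a morpholine, an unsubstituted piperazine or an open-chain dimethylamino group would give at this place. Among the compounds shown here, also open is whether the exchange would cost as much without the chloro: compound 2, the only compound lacking it, carries the 4-methylpiperazin-1-yl group.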